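This account rests on a few compounds, and the source may have more. Where it says the series, first, only, none or still open, it means among the compounds named here.

Measured compounds:
compound 1, `Cc1ccccc1OCC1=NCCO1`: 100%
compound 2, `Clc1ccccc1OCC1=NCCO1`: 60%

Among the compounds with values here, in a toxicity assay on the whole organism with Rattus norvegicus as the target, at a dose of 400 mg/kg by the oral route (a higher number here means a stronger effect of the compound at the dose given, a lower number a weaker effect), compound 1 stands highest of the two numbers; the only measured step is a number 40 percentage points lower from compound 1 to compound 2 (beyond the scatter), a change of chloro in place of methyl on an aromatic carbon. Compound 3, `Cc1ccc(OCC2=NCCO2)c(C)c1`, differs from compound 1 by methyl in place of hydrogen on an aromatic carbon. Within the data shown here, no measured step adds a methyl in place of hydrogen, so the one known step does not bear directly on this change. Compound 1 already stands at the top of the observed numbers, and the step from compound 1 to compound 3 is therefore expected to be none beyond the scatter, a number 10 percentage points lower from compound 1 to compound 3 (within the scatter). For compound 3 the estimate in this assay is 90%, ranging from 70% to 100%.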

Compound 3, a percentage reported as activity, at one dose (the size of the read-out at that dose, not a potency): 75%
Compound 3: middle estimate off by 15 percentage points, on the high side; the range from low to high includes it.
By their numbers in this assay, from the lowest: compound 2; then compound 3; then compound 1.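

At the aromatic carbon meta to a methyl group and para to a group of 7 heavy atoms, the added methyl gives a number 25 percentage points lower from compound 1 to compound 3 (beyond the scatter) in this assay. The earlier compounds shown here showed a change only at the existing methyl group, whereas this result shows that a second place on the ring also affects the read-out. Nothing shown accounts for this step.

The compounds shown leave open how a methoxy group or an amine at this carbon would read out. They also leave open whether a methyl on another aromatic carbon would give a similar step.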